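Swapping the dichlorophenyl amide for a trifluoromethylphenyl

The source may report more compounds than this note shows. Statements on the series, on what has been measured and on what is new or still open speak of the compounds shown alone.

Measured compounds:
compound 1 `CN(C(=O)NC(=O)c1ccc(Cl)cc1Cl)c1nc(C(F)(F)F)c(C(=O)N/N=C/c2cccc(C(F)(F)F)c2)s1`: 11.2 ug/mL
compound 2 `CN(C(=O)NC(=O)c1ccc(Cl)cc1Cl)c1nc(C(F)(F)F)c(C(=O)N/N=C/c2cc(C(F)(F)F)cc(C(F)(F)F)c2)s1`: > 100 ug/mL

In a functional assay on HepG2 cells (Homo sapiens) for inhibition, read by MTT assay, with a stated time of 72 h (on this read-out higher numbers stand for weaker inhibition and lower numbers for stronger inhibition), compound 1 gives 11.2 ug/mL. Compound 2 reaches only the limit (the limit of > 100 ug/mL in this assay, at which 1 of the 2 values shown sits), so its number is not known. Among the compounds with values here, the one measured step, an at least 8.9-fold higher number from compound 1 to compound 2 (0.95 log units; beyond the scatter), changes a different part of the molecule.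

Compound 3 `CN(C(=O)NC(=O)c1ccc(C(F)(F)F)cc1)c1nc(C(F)(F)F)c(C(=O)N/N=C/c2cc(C(F)(F)F)cc(C(F)(F)F)c2)s1` differs from compound 2 by 4-(trifluoromethyl)phenyl in place of 2,4-dichlorophenyl on a carbonyl carbon. Within the data shown here, no measured step touches this position, so no size or direction can be drawn from the data. Compound 3 is therefore expected to stay near the limit, with the step of a number no higher from compound 2 to compound 3 (the limit leaves the size open) reflecting only that guess. Compound 3 is estimated at 100 ug/mL, in the range 30 ug/mL to 300 ug/mL.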

Compound 3, half-maximal inhibitory concentration: 8.35 ug/mL
The estimate for compound 3 lay 12-fold (1.08 log units) above the measured number; measured number outside the range, below it.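

In this assay, placing 4-(trifluoromethyl)phenyl on the carbonyl carbon instead of 2,4-dichlorophenyl gives an at least 11-fold lower number from compound 2 to compound 3 (1.07 log units; beyond the scatter), so this position, untouched by the earlier step, clearly matters. Compound 2 has only a limit, so the true size of the step is unknown: the limit of > 100 ug/mL in this assay, at which 1 of the 3 values shown sits.

Compound 3 keeps the ring with two trifluoromethyl groups, so that ring does not by itself abolish inhibition.

Losing the chlorine atoms and gaining the trifluoromethyl group happen together here, and their separate contributions remain unclear. On these data alone, how an amine or a carboxylic acid on that ring would behave also remains open.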